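The source may report more compounds than this note shows. Statements on the series, on what has been measured and on what is new or still open speak of the compounds shown alone.

Measured so far in a functional assay on the whole organism (strain Sprague-Dawley) for inhibition, with Rattus norvegicus as the target; on this read-out lower numbers stand for an effect already at smaller amounts and higher numbers for an effect only at larger amounts of compound:
compound 1 `O=c1c(-c2nn[nH]n2)c[nH]c2c(F)ccc(F)c12`: > 0.156 mg/kg, a limit of the assay rather than a number
compound 2 `O=c1c(-c2nn[nH]n2)c[nH]c2c(Br)cccc12`: > 5 mg/kg, likewise only a limit
compound 3 `O=c1c(-c2nn[nH]n2)c[nH]c2c(F)cccc12`: 0.625 mg/kg

Going by the values given here, compound 3 stands as the only compound of the three with a read number in this assay; the other two values are limits (the limit of > 0.156 mg/kg in this assay, at which 1 of the 3 values shown sits, and (the limit of > 5 mg/kg in this assay, at which 1 of the 3 values shown sits)), so no order among the three beyond those limits can be drawn. The step from compound 1 to compound 3 (a step that the limit leaves unreadable from compound 1 to compound 3) therefore stays unreadable. Among the compounds with values here, the one readable step is an at least 8.0-fold lower number from compound 2 to compound 3 (0.90 log units; beyond the scatter), which is at least modest and beyond the scatter.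

Compound 4 `CC(C)c1cccc2c(=O)c(-c3nn[nH]n3)c[nH]c12` differs from compound 3 in one place: isopropyl in place of fluoro on an aromatic carbon. Of the measured steps only the exchange at this same aromatic carbon bears on it, and there the bromo analogue, compound 2, gave the higher number, read only as a limit. With three heavy atoms entering where one leaves, a step in the same direction is expected, and a limit rather than a number is a real possibility. For compound 4 the expected step is an 8.0-fold higher number from compound 3 to compound 4 (0.90 log units; beyond the scatter), giving an estimate of 5 mg/kg, within a range from 1.25 mg/kg to 20 mg/kg.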

Compound 4, minimum effective dose: 1.25 mg/kg
For compound 4 the middle estimate is 4.0-fold (0.60 log units) above the measured one; the range from low to high includes it.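

In this assay, isopropyl in place of fluoro on this aromatic carbon gives a 2.0-fold higher number from compound 3 to compound 4 (0.30 log units; within the scatter), so compound 3 and compound 4 are not separated, and the position takes isopropyl as well as fluoro and still gives a read number. Isopropyl in place of bromo gives an at least 4.0-fold lower number from compound 2 to compound 4 (0.60 log units; beyond the scatter), so the order at this position does not simply follow the number of heavy atoms in the group, with compound 2 standing apart from compound 3 and compound 4. That step has only a minimum size, as compound 2 is read only as a limit: the limit of > 5 mg/kg in this assay, at which 1 of the 4 values shown sits.

The compounds shown leave open what a longer chain, an amine or a carboxylic acid would give on this aromatic carbon, and they offer no explanation of why compound 2 stands apart. As far as these compounds go, the step from compound 1 to compound 3 cannot be read, so what the second fluoro on the core of compound 1 contributes also stays open.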